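The source may hold more compounds than are shown below. What is called first, only, known or untested is meant among the compounds shown, and "the series" means these compounds.

Compound 3 `Cc1ccc2cc(CN(Cc3ccc(F)cc3)Cc3ccc(C(F)(F)F)cc3)c(=O)[nH]c2c1` is tested in a toxicity assay on MDCK cells (Canis lupus familiaris) for cytotoxicity, read by crystal violet staining, with a stated time of 48 h (on this read-out lower numbers stand for higher toxicity in this test and higher numbers for lower toxicity in this test), and gives only a limit of the assay, > 33000 nM. Compound 1 `Cc1ccc2cc(CN(Cc3ccc(F)cc3)Cc3ccc(C(C)C)cc3)c(=O)[nH]c2c1` likewise gives only a limit in this assay, > 33000 nM. Compound 2 `CCc1ccc(CN(Cc2ccc(F)cc2)Cc2cc3ccc(C)cc3[nH]c2=O)cc1` also gives only a limit in this assay, > 33000 nM. All three values sit on (the limit of > 33000 nM in this assay, at which 3 of the 3 values shown sit), and so none of the steps among these compounds can be read: a step that the two limits leave unreadable from compound 1 to compound 2, a step that the two limits leave unreadable from compound 1 to compound 3 and a step that the two limits leave unreadable from compound 2 to compound 3 all remain without a size. Compound 4 `Cc1ccc2cc(CNCc3ccc(F)cc3)c(=O)[nH]c2c1` is not yet measured. It differs from compound 3 by hydrogen in place of 4-(trifluoromethyl)benzyl on an amine nitrogen. The measured steps concern only the substituent on the benzyl group that is now removed entirely, and none of them yielded a number, so they carry no readable size over to this larger change. The expectation for the step from compound 3 to compound 4 is therefore a step that the limit leaves unreadable from compound 3 to compound 4, a step that the scatter and the limit would most likely leave unreadable again. For compound 4 the estimate in this assay is 50000 nM, expected to fall within a range from 15000 nM to 200000 nM, and most probably reported once more only as a limit.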

Compound 4, half-maximal cytotoxic concentration: > 33000 nM
Compound 4 was reported as a limit; the forecaster's own chance of this, stated with the estimate: 80%; the middle value does not contradict the limit.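

Compound 4, like compound 1, compound 2 and compound 3, gives only a limit in this assay, so none of the steps from those three compounds to compound 4 can be read: the limit of > 33000 nM in this assay, at which 4 of the 4 values shown sit. The compounds shown leave open what the half-maximal cytotoxic concentration of each one actually is, and whether removing the substituted benzyl group changes it at all.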